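Replacing a bromophenyl ring with pyridinyl on a cinnamamide

The source may hold more compounds than are shown below. What is called first, only, known or untested is meant among the compounds shown, and "the series" means these compounds.

Two close relatives set the stage. Compound 1, `COc1cc(/C=C/c2ccc(NC(=O)/C=C/c3ccccc3F)cc2)cc(OC)c1`, and compound 2, `COc1cc(/C=C/c2ccc(NC(=O)/C=C/c3ccc(Br)cc3)cc2)cc(OC)c1`, share one core and differ only in the ring that sits on a double-bonded chain carbon bound to a double-bonded chain carbon. In a functional assay on HT-29 cells (Homo sapiens) for inhibition, read by MTT assay, with a stated time of 48 h (on this read-out higher numbers stand for weaker inhibition and lower numbers for stronger inhibition), compound 1 gives 2820 nM, and in this assay compound 2 gives 5260 nM. Of the two numbers, compound 2 is the higher one, yet the step of a 1.9-fold higher number from compound 1 to compound 2 (0.27 log units; within the scatter) stays within the scatter, so the two compounds cannot be told apart on these data.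

Compound 3, `COc1cc(/C=C/c2ccc(NC(=O)/C=C/c3ccccn3)cc2)cc(OC)c1`, changes the same ring once more: pyridin-2-yl in place of 4-bromophenyl on a double-bonded chain carbon bound to a double-bonded chain carbon. For the measured compounds named here, the only measured step that touches this position is the one from compound 1 to compound 2, and it was within the scatter. Nothing here shows that swapping this ring moves the number, though a ring with a nitrogen has not yet been tried. Compound 3 is therefore expected to land close to compound 2, with the step of a 1.3-fold lower number from compound 2 to compound 3 (0.12 log units; within the scatter) reflecting only a small, uncertain shift. The estimate for compound 3 is 4000 nM, with a range from 1500 nM to 12000 nM.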

Compound 3, half-maximal inhibitory concentration: 6120 nM
For compound 3 the middle estimate is 1.5-fold (0.18 log units) below the measured one; measured number inside the range.
By their numbers in this assay, from the lowest: compounds 1, 2 and 3 (each within the scatter of the next, the first and the last beyond it).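

Pyridin-2-yl is the first ring at this position to carry a hetero atom and a hydrogen-bond acceptor, and in this assay putting it in place of 4-bromophenyl gives a 1.2-fold higher number from compound 2 to compound 3 (0.07 log units; within the scatter) so these two compounds cannot be told apart. Set against the 2-fluorophenyl ring, the same pyridin-2-yl ring gives a 2.2-fold higher number from compound 1 to compound 3 (0.34 log units; beyond the scatter) and this is the first step at this position to clear the scatter, although only modestly. So a ring nitrogen is tolerated here without any clear gain, and across the three rings shown the numbers stay close together, with only the two ends of the series distinguishable. Nothing in the data shown accounts for these small differences.

The compounds shown leave open how a pyridin-3-yl or pyridin-4-yl ring would compare, which would show whether the place of the nitrogen within the ring matters. Also open, going by these compounds, is how an unsubstituted phenyl ring, or a phenyl ring bearing an amine or a carboxylic acid, would read on this position.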